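This account rests on a few compounds, and the source may have more. Where it says the series, first, only, none or still open, it means among the compounds named here.

Compound 1 `CC(=N)N1CCC(Oc2ccc3c(c2)nc(C(C)C)n3Cc2ccc3ccc(C(=N)N)cc3c2)CC1` is measured in an assay on isolated protein for inhibition of serine protease 1 (Bos taurus) (a lower number here means a stronger inhibitor, a higher number a weaker inhibitor), at 16 nM, the second highest of three numbers. Going by the values given here, compound 2 `CC(=N)N1CCC(Oc2ccc3nc(CCC(N)=O)n(Cc4ccc5ccc(C(=N)N)cc5c4)c3c2)CC1` gives 4.4 nM in this assay, and compound 3 `CC(=N)N1CCC(Oc2ccc3nc(CCC(=O)O)n(Cc4ccc5ccc(C(=N)N)cc5c4)c3c2)CC1` gives 18 nM; the only single-point step, a 4.1-fold higher number from compound 2 to compound 3 (0.61 log units; beyond the scatter), concerns a change at the chain end, not the change at hand. Compound 4 `CCc1nc2cc(OC3CCN(C(C)=N)CC3)ccc2n1Cc1ccc2ccc(C(=N)N)cc2c1` differs from compound 1 by hydrogen in place of methyl on a saturated chain carbon bound to an aromatic carbon and a saturated chain carbon. Among the compounds with values here, no measured step bears directly on this trimming of the chain, so the expectation rests on the small size of the change alone. Compound 4 is therefore expected to land close to compound 1, with no change at the digits printed from compound 1 to compound 4 (within the scatter) as the estimated step. The estimated value for compound 4 in this assay is 16 nM, within a range of 6 nM to 45 nM.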

Compound 4, inhibition constant: 17 nM
Beside the measured number, compound 4's estimate is 1.1-fold (0.03 log units) below it; low and high end bracket the measured number.
By their numbers in this assay, from the lowest: compound 2; then compounds 1, 4 and 3 (each within the scatter of the next).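

In this assay, going from isopropyl to ethyl gives a small step (a 1.1-fold higher number from compound 1 to compound 4 (0.03 log units; within the scatter)), so at this place the loss of one methyl cannot be told from the scatter. Going by these compounds alone, the only earlier step concerned the end of a carbonyl-bearing chain and said nothing about trimming this small alkyl group. No evidence here explains why the number holds.

As far as these compounds go, it remains open how far this tolerance extends: whether a bulkier tert-butyl group or a simple methyl at the same place would also leave the number within the scatter.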